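Moving a hydroxyl around the phenyl ring

The source may hold more compounds than are shown below. What is called first, only, known or untested is meant among the compounds shown, and "the series" means these compounds.

Three compounds with a shared core carry two hydroxyphenyl groups and a five-membered heteroaromatic ring. Compound 1 `Oc1ccc(-c2cc(-c3ccsc3)cc(-c3ccccc3O)n2)cc1` in an assay on isolated protein for inhibition of DNA topoisomerase 1 (Homo sapiens), with a stated time of 30 min, tested at 20 uM (a higher number here means a stronger effect of the compound at the concentration tested, a lower number a weaker effect), has the entry "not determined" (no result reported), so no number is available for it. Compound 2 `Oc1ccc(-c2cc(-c3ccsc3)cc(-c3ccc(O)cc3)n2)cc1` gives 7.5% in this assay. Compound 3 `Oc1ccc(-c2cc(-c3ccco3)cc(-c3ccccc3O)n2)cc1` gives 0% in this assay. The values of compound 2 and compound 3 lie within the usual scatter of one another, so compound 3 cannot be told apart from compound 2 on these numbers; both sit close to no measurable inhibition.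

Compound 4 `Oc1ccc(-c2cc(-c3ccco3)cc(-c3ccc(O)cc3)n2)cc1` is compound 3 with one change (4-hydroxyphenyl in place of 2-hydroxyphenyl on an aromatic carbon). Going by the values given here, the same kind of change separates compound 1 from compound 2, but with no number for compound 1 it gives no measured step to lean on. Since both reported values sit near zero, no step beyond the scatter is expected in this assay from compound 3 to compound 4, and the expected step is a number 4 percentage points higher from compound 3 to compound 4 (within the scatter). Compound 4 is therefore estimated to give 4% in this assay, within a range from 0% to 15%.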

Compound 4, a percentage reported as inhibition, at one concentration (the size of the read-out at that concentration, not a potency): 0%
For compound 4 the middle estimate is 4 percentage points above the measured one, within the range that was stated.
By their numbers in this assay, from the lowest: compounds 3, 4 and 2 (each within the scatter of the next).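

In this assay, going by these compounds alone, moving the hydroxyl from 2-hydroxyphenyl to 4-hydroxyphenyl at this position gives no change at the digits printed from compound 3 to compound 4 (within the scatter) and provides the first measured step for this change, with a furan-2-yl group on the shared core. The second new step, furan-2-yl in place of thiophen-3-yl with both 4-hydroxyphenyl groups kept, gives a number 7.5 percentage points lower from compound 2 to compound 4 (within the scatter) and so cannot be told apart from no effect at the single concentration tested. Nothing shown here offers an explanation for these results.

As far as these compounds go, whether the same hydroxyl move behaves alike with thiophen-3-yl on the core remains open. Also open, from the compounds shown here alone, is whether an amine or a carboxylic acid in place of this hydroxyl, or a longer chain in place of the five-membered ring, would lift the read-out clear of the scatter.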